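Formyl to acetyl: an oral bioavailability estimate

The compounds below may be only part of what the source reports. "The series", "measured", "known", "first", "only" and "open" are said of these compounds alone.

Within the data shown here, in an ADME assay on the whole organism (Rattus norvegicus, strain Harlan-Han Wistar) for pharmacokinetics, at a dose of 2.8 mg/kg by the oral route (a lower number here means that a smaller share of the oral dose reaches the circulation, a higher number that a larger share of the oral dose reaches the circulation), compound 1 `CN1CCC[C@H](NC(=O)[C@H]2CN(S(=O)(=O)c3ccccc3)C[C@@H]2NC(=O)c2cc(-c3ccccc3Cl)on2)C1` gives 9% and compound 2 `O=CN1CCC[C@H](NC(=O)[C@H]2CN(S(=O)(=O)c3ccccc3)C[C@@H]2NC(=O)c2cc(-c3ccccc3Cl)on2)C1` gives 4%, so compound 2 stands within the scatter of its only measured neighbour. Compound 3 `CC(=O)N1CCC[C@H](NC(=O)[C@H]2CN(S(=O)(=O)c3ccccc3)C[C@@H]2NC(=O)c2cc(-c3ccccc3Cl)on2)C1` differs from compound 2 by methyl in place of hydrogen on a carbonyl carbon, which turns formyl to acetyl. Among the measured compounds shown here, one measured step bears on this change, formyl in place of methyl on an amine nitrogen in a ring. Since the step of a number 5 percentage points lower from compound 1 to compound 2 (within the scatter) stays small, no step beyond the scatter is expected in this assay. The expected step is a number 2 percentage points higher from compound 2 to compound 3 (within the scatter). Compound 3 is estimated at 6%, with an expected range of 1% to 15%.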

Compound 3, oral bioavailability: < 1%
Compound 3: no number, only a limit; the forecaster's own chance of this, stated with the estimate: 5%; at least 5 percentage points between middle value and limit.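

In this assay compound 3 gives < 1%, which is a limit and not a number. The acetyl group therefore gives only floors: a number at least 3 percentage points lower from compound 2 to compound 3 (that floor lies within the scatter) and a number at least 8 percentage points lower from compound 1 to compound 3 (that floor lies within the scatter). With methyl, formyl and acetyl on this amine nitrogen in a ring, no step is yet shown beyond the scatter, and the true size of both steps cannot be read: the limit of < 1% in this assay, at which 1 of the 3 values shown sits.

Going by these compounds, whether a longer chain on the carbonyl carbon, or a carboxylic acid at this nitrogen, would give a step beyond the scatter stays open.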